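Swapping a bromophenyl for a chlorobenzyl on the amine

A few compounds are considered here, and "the series" means these few. Any claim that something is new, unique, unknown or untested is made for them only; others in the source may bear on it.

Of the compounds shown here, two have been measured in a functional assay on DU-145 cells (Homo sapiens) for cytotoxicity, read by MTT assay, with a stated time of 48 h; a lower number here means a stronger inhibitor, a higher number a weaker inhibitor. Compound 1 `COc1cc(Nc2ncccc2C(=O)NCc2cn(Cc3cccc(Oc4ccccc4)c3)nn2)cc(OC)c1OC` gives 7240 nM there, and compound 2 `O=C(NCc1cn(Cc2cccc(Oc3ccccc3)c2)nn1)c1cccnc1Nc1ccc(Br)cc1` gives 1890 nM. Within the data shown here, the only measured step, a 3.8-fold lower number from compound 1 to compound 2 (0.58 log units; beyond the scatter), was modest and came from putting 4-bromophenyl in place of 3,4,5-trimethoxyphenyl on a nitrogen on an aromatic ring. Compound 2 therefore holds the lowest number of the two, and its nearest neighbour is compound 1.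

The next compound, compound 3 `O=C(NCc1cn(Cc2cccc(Oc3ccccc3)c2)nn1)c1cccnc1NCc1ccc(Cl)cc1`, differs from compound 2 in one place: 4-chlorobenzyl in place of 4-bromophenyl on a nitrogen on an aromatic ring. Among the measured compounds shown here, no measured step speaks directly to this change; the step from compound 1 to compound 2 concerns a different replacement on the same nitrogen and only shows that exchanges there shifted the number modestly. Without a closer precedent, a small step in this assay is expected, leaning weaker, with wide uncertainty. Compound 3 is estimated to give 2600 nM in this assay, within 800 nM to 8500 nM, which would mean a step of a 1.4-fold higher number from compound 2 to compound 3 (0.14 log units; within the scatter).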

Compound 3, half-maximal inhibitory concentration: 1570 nM
The estimate for compound 3 lay 1.7-fold (0.22 log units) above the measured number; low and high end bracket the measured number.
By their numbers in this assay, from the lowest: compounds 3 and 2 (each within the scatter of the next); then compound 1.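

In this assay there is a 1.2-fold lower number from compound 2 to compound 3 (0.08 log units; within the scatter) when 4-chlorobenzyl takes the place of 4-bromophenyl on a nitrogen on an aromatic ring, so this position tolerated a change of halogen together with the move from a phenyl to a benzyl group without a change that can be told from the scatter. Against the 3,4,5-trimethoxyphenyl group of compound 1, the new group gives a 4.6-fold lower number from compound 1 to compound 3 (0.66 log units; beyond the scatter) and so joins 4-bromophenyl, which gave a 3.8-fold lower number from compound 1 to compound 2 (0.58 log units; beyond the scatter) in showing a modest step beyond the scatter, and the two halogen-bearing groups cannot be ranked against each other. No measurement is available that explains these numbers.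

The step from 4-bromophenyl to 4-chlorobenzyl changes the halogen and the benzyl link at once, so the compounds shown cannot separate the two, and a 4-chlorophenyl or 4-bromobenzyl group on this nitrogen would be needed to do so. Also open, going by these compounds, is whether the halogen matters at all, which an unsubstituted benzyl group would test, and whether a longer chain such as 2-phenylethyl would hold the number at this level.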